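The source may hold more compounds than are shown below. What is called first, only, known or untested is meant among the compounds shown, and "the series" means these compounds.

For the measured compounds named here, compound 1, whose structure is `COc1cc(-c2ccnc3cc(-c4ccc(C(F)(F)F)cc4)nn23)cc(OC)c1OC`, is the only compound of this series with a measured number in a functional assay on HCT-116 cells (Homo sapiens) for inhibition, read by CCK-8 assay, with a stated time of 48 h; a lower number here means a stronger inhibitor, a higher number a weaker inhibitor: compound 1 gives 1860 nM. Compound 2, `CCOC(=O)c1ccc(-c2cc3nccc(-c4cc(OC)c(OC)c(OC)c4)n3n2)cc1`, was also tested, and in this assay compound 2 reaches only the limit of the assay, > 10000 nM. The step between them is an at least 5.3-fold higher number from compound 1 to compound 2 (0.73 log units; beyond the scatter), with the change being ethoxycarbonyl in place of trifluoromethyl on an aromatic carbon; compound 2 sits at the limit of > 10000 nM in this assay, at which 1 of the 2 values shown sits.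

Compound 3, `COc1ccc(-c2cc3nccc(-c4cc(OC)c(OC)c(OC)c4)n3n2)cc1N`, has not yet been measured. It differs from compound 1 as follows: 3-amino-4-methoxyphenyl in place of 4-(trifluoromethyl)phenyl on an aromatic carbon. Going by the values given here, the one measured step that bears on this position is the step to compound 2, which brought a clear weakening once the trifluoromethyl was exchanged. Since compound 3 also exchanges the trifluoromethyl for a different group, a weakening is expected, though its size is uncertain; the expected step is a 2.4-fold higher number from compound 1 to compound 3 (0.38 log units; beyond the scatter). For compound 3 the expected value in this assay is 4500 nM, with a range from 1200 nM to 15000 nM.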

Compound 3, half-maximal inhibitory concentration: 251 nM
Compound 3: the middle estimate sits 18-fold (1.25 log units) above what was measured; measured number below the stated range.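

Compound 3 shows that the 4-(trifluoromethyl)phenyl group is not required at this position on the five-membered aromatic ring: exchanging it for 3-amino-4-methoxyphenyl gives a 7.4-fold lower number from compound 1 to compound 3 (0.87 log units; beyond the scatter) in this assay. The earlier compounds shown here showed only a loss on changing this group, and that step, an at least 5.3-fold higher number from compound 1 to compound 2 (0.73 log units; beyond the scatter), rests on a limit of the assay, so the two changes at this position now run in opposite directions and the outcome clearly depends on what replaces the trifluoromethyl-bearing ring. Nothing measured here gives a cause for the gain seen with compound 3.

The compounds shown leave open how the gain is shared between the amine and the methoxy group on the new ring, and whether a hydroxyl or an acetamide in place of that amine would keep it. Also open, going by these compounds, is whether an ethoxy group in place of that methoxy, or a carboxylic acid elsewhere on the same ring, would strengthen or weaken the result in this cell assay.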